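From methyl to benzyl: a step not yet measured

This account rests on a few compounds, and the source may have more. Where it says the series, first, only, none or still open, it means among the compounds named here.

Among the compounds with values here, in an ADME assay on HEK-293T cells (Homo sapiens) for cytotoxicity, read by CCK-8 assay, with a stated time of 24 h (a higher number here means that more compound is tolerated, a lower number that less compound is tolerated), compound 2 `CN(Cc1ccccc1)C(=O)CSc1c[nH]c2cccc(Br)c12` gives 25100 nM, the only true number so far. Compound 1 `O=C(CSc1c[nH]c2ccccc12)N(Cc1ccccc1)Cc1ccccc1` gives > 100000 nM, which is a limit of the assay. Compound 3 `O=C(CSc1c[nH]c2cccc(Br)c12)N(Cc1ccccc1)Cc1ccccc1` differs from compound 2 by one change, phenyl in place of hydrogen on a saturated chain carbon bound to an amide-type nitrogen, so methyl becomes benzyl. Within the data shown here, no measured step shows this change, so no shift beyond the scatter is expected in this assay. The expected change is a 1.2-fold higher number from compound 2 to compound 3 (0.08 log units; within the scatter). For compound 3 the estimated value is 30000 nM, within an expected range of 11000 nM to 90000 nM.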

Compound 3, half-maximal cytotoxic concentration: 25700 nM
Compound 3: the middle estimate sits 1.2-fold (0.07 log units) above what was measured, and the stated range covers the measured number.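

In this assay, phenyl in place of hydrogen on a saturated chain carbon bound to an amide-type nitrogen gives a 1.0-fold higher number from compound 2 to compound 3 (0.01 log units; within the scatter), so at this place methyl and benzyl cannot be told apart. Bromo in place of hydrogen on an aromatic carbon gives an at least 3.8-fold lower number from compound 1 to compound 3 (0.59 log units; beyond the scatter), the first measured step here that lies beyond the scatter. Compound 1 has only a limit, not a true number: the limit of > 100000 nM in this assay, at which 1 of the 3 values shown sits.

From the compounds shown here alone, whether an amine or a carboxylic acid on that chain would move the number stays open. So does the effect of chloro in place of bromo.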